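Aryl variation on the shared core: compound 4

This account rests on a few compounds, and the source may have more. Where it says the series, first, only, none or still open, it means among the compounds named here.

Three compounds share one core and differ only in the aryl group on the amine nitrogen in the ring. Compound 1 `Cc1ccc(N2CCN(C(=S)N/N=C3\C(=O)Nc4ccc(Cl)cc43)CC2)c(C)c1` gives 10800 nM in a functional assay on MCF7 cells (Homo sapiens) for inhibition, read by MTT assay, with a stated time of 72 h; on this read-out higher numbers stand for weaker inhibition and lower numbers for stronger inhibition. Compound 2 `O=C1Nc2ccc(Cl)cc2/C1=N/NC(=S)N1CCN(c2ccc(Cl)cc2)CC1` gives 13100 nM in this assay, and compound 3 `O=C1Nc2ccc(Cl)cc2/C1=N/NC(=S)N1CCN(c2ccccc2F)CC1` gives 15200 nM. Compound 3 thus has the highest of the three numbers, but the steps of a 1.4-fold higher number from compound 1 to compound 3 (0.15 log units; within the scatter) and a 1.2-fold higher number from compound 2 to compound 3 (0.06 log units; within the scatter) both fall within the scatter, as does a 1.2-fold higher number from compound 1 to compound 2 (0.08 log units; within the scatter), so the three aryl groups are not separated on this read-out.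

Compound 4 `O=C1Nc2ccc(Cl)cc2/C1=N/NC(=S)N1CCN(c2ccccc2[N+](=O)[O-])CC1` is compound 3 with nitro in place of fluoro on an aromatic carbon. Within the data shown here, no measured step replaces a fluoro with a nitro, so nothing bears directly on this change; the only relevant evidence is that every exchange of the aryl group so far, covering a 2,4-dimethylphenyl, a 4-chlorophenyl and a 2-fluorophenyl, moved the number by less than the scatter. On that basis the step of a 1.0-fold lower number from compound 3 to compound 4 (0.01 log units; within the scatter) is expected to stay within the scatter, with no direction favoured. Compound 4 is therefore estimated at 15000 nM in this assay, with a range of 6000 nM to 40000 nM, the width allowing for the untested nature of the nitro group.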

Compound 4, half-maximal inhibitory concentration: 7490 nM
Compound 4: middle estimate off by 2.0-fold (0.30 log units), on the high side; low and high end bracket the measured number.
By their numbers in this assay, from the lowest: compounds 4, 1, 2 and 3 (each within the scatter of the next, the first and the last beyond it).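

In this assay the step of a 2.0-fold lower number from compound 3 to compound 4 (0.31 log units; beyond the scatter) is the only one among these four compounds that lies beyond the scatter, which shows that a change on this aromatic carbon, ortho to a large group, can register on this read-out, where the earlier aryl exchanges did not separate. The separation is narrow and limited to this one pair: the steps of a 1.7-fold lower number from compound 2 to compound 4 (0.24 log units; within the scatter) and a 1.4-fold lower number from compound 1 to compound 4 (0.16 log units; within the scatter) both stay within the scatter, so the 2-nitrophenyl group stands apart from the 2-fluorophenyl group but not from the 4-chlorophenyl or 2,4-dimethylphenyl groups. Nothing measured on these compounds accounts for the step between the 2-fluorophenyl and 2-nitrophenyl groups.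

The compounds shown leave open whether the step belongs to nitro itself or would also appear with another group on the same carbon, such as an amine, a methoxy group or a carboxylic acid. They also leave open whether nitro on a different carbon of the same aromatic ring would give a comparable number, and whether any aryl group can move this series further than this modest step.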